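Methylation of a Ring Hydroxyl in Chalcone 5-Lipoxygenase Inhibitors

The source may report more compounds than this note shows. Statements on the series, on what has been measured and on what is new or still open speak of the compounds shown alone.

Three chalcones sharing one core have been measured in an assay on RBL-1 cells for inhibition of Polyunsaturated fatty acid 5-lipoxygenase (Rattus norvegicus); on this read-out higher numbers stand for weaker inhibition and lower numbers for stronger inhibition. Compound 1, `COc1ccc(C(=O)/C=C/c2ccc(O)c(OC)c2)cc1`, gives 12000 nM. Compound 2, `COc1ccc(C(=O)/C=C/c2ccc(O)c(O)c2)cc1`, gives 20 nM. Compound 3, `CCOc1ccc(O)c(C(=O)/C=C/c2ccc(O)c(O)c2)c1`, gives 5.3 nM, the lowest of the three numbers. The difference between the cores of compound 2 and compound 3 is not broken down here.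

Compound 2 and compound 1 differ only by methyl in place of hydrogen on an oxygen on an aromatic ring, and this change produced a 600-fold higher number from compound 2 to compound 1 (2.78 log units; beyond the scatter). The same change, (methyl in place of hydrogen on an oxygen on an aromatic ring), leads from compound 3 to compound 4, `CCOc1ccc(OC)c(C(=O)/C=C/c2ccc(O)c(O)c2)c1`, which remains to be measured in this assay. Among the compounds shown it occurs twice in all.

A weaker effect is expected in this case: where compound 3 carries the hydroxy, compound 2 carries a hydrogen and gives 20 nM, so capping that hydroxy is expected to cost less than the step seen from compound 2 to compound 1. The step from compound 3 to compound 4 is estimated as a 3.8-fold higher number from compound 3 to compound 4 (0.58 log units; beyond the scatter). Compound 4 is expected to give about 20 nM, within 5 nM to 80 nM.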

Compound 4, half-maximal inhibitory concentration: 3.8 nM
The estimate for compound 4 lay 5.3-fold (0.72 log units) above the measured number; measured number outside the range, below it.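

In this assay, methyl in place of hydrogen on an oxygen on an aromatic ring gave a 1.4-fold lower number from compound 3 to compound 4 (0.14 log units; within the scatter), so the large step seen on the core of compound 2 did not recur on the core of compound 3. The size of this change therefore cannot be carried from one of these cores to the other, as the two steps differ: the same change on two cores in this assay, a 600-fold higher number (2.78 log units; beyond the scatter) from compound 2 to compound 1 and a 1.4-fold lower number (0.14 log units; within the scatter) from compound 3 to compound 4, 840-fold (2.92 log units) apart, beyond the scatter of two such steps. For the compounds shown here, this shows that the outcome of the change depends on the core, but it does not show which feature of the core decides it, since the cores of compound 2 and compound 3 differ in a way not broken down here and only two pairs are available.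

The compounds shown leave open whether a longer chain, such as propyl, on the same oxygen would also leave the number close to that of compound 3. They also leave open what an amine or a carboxylic acid at the end of such a chain would do on either core.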